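Notes on the step from compound 1 to compound 4

This account rests on a few compounds, and the source may have more. Where it says the series, first, only, none or still open, it means among the compounds named here.

In a functional assay on HepG2 cells (Homo sapiens) for antiproliferative activity, read by MTT assay, with a stated time of 48 h (on this read-out higher numbers stand for weaker inhibition and lower numbers for stronger inhibition), compound 1 (`CN(C)c1ccc(NC(=O)Nc2cccc(CNc3nccnc3Cl)c2)cc1`) gives > 40000 nM, which is a limit of the assay and not a number. Compound 1 therefore stands at the limit of > 40000 nM in this assay, at which 1 of the 3 values shown sits.

The two other measured compounds give numbers. Compound 2 (`Cc1cccc(NC(=O)Nc2cccc(CNc3nccnc3Cl)c2)c1`) gives 11200 nM, and compound 3 (`O=C(Nc1cccc(CNc2nccnc2Cl)c1)Nc1ccc(F)c(Cl)c1`) gives 6750 nM. Between these two there is a 1.7-fold lower number from compound 2 to compound 3 (0.22 log units; within the scatter).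

Compound 4 (`O=C(Nc1cccc(CNc2nccnc2Cl)c1)Nc1ccccc1F`) has not yet been measured. It differs from compound 1 in one place, with 2-fluorophenyl in place of 4-(dimethylamino)phenyl on an amide-type nitrogen.

Two measured steps remove the same 4-(dimethylamino)phenyl group and bear on this change. With 3-methylphenyl entering, the result is an at least 3.5-fold lower number from compound 1 to compound 2 (0.55 log units; beyond the scatter). With 3-chloro-4-fluorophenyl entering, the result is an at least 5.9-fold lower number from compound 1 to compound 3 (0.77 log units; beyond the scatter). Neither step brings in 2-fluorophenyl, so the transfer to compound 4 is an extrapolation from the shared core.

Both replacements lowered the number, so a step of similar size in the same direction, towards stronger inhibition, is expected in this assay. The estimated change is an at least 4.0-fold lower number from compound 1 to compound 4 (0.60 log units; beyond the scatter). For compound 4 the expected value is 10000 nM, with an estimated range from 4500 nM to 28000 nM.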

Compound 4, half-maximal inhibitory concentration: 10500 nM
Compound 4: the middle estimate sits 1.1-fold (0.02 log units) below what was measured; measured number inside the range.
By their numbers in this assay, from the lowest: compounds 3, 4 and 2 (each within the scatter of the next). At a limit, above all of these: compound 1.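

In this assay, 2-fluorophenyl on the amide-type nitrogen gives an at least 3.8-fold lower number from compound 1 to compound 4 (0.58 log units; beyond the scatter), so a third group in place of 4-(dimethylamino)phenyl now gives a step beyond the scatter, and this one brings in a single fluorine and no chlorine or methyl. Among these compounds, the three entering groups cannot be told apart at this place, with a 1.6-fold higher number from compound 3 to compound 4 (0.19 log units; within the scatter) and a 1.1-fold lower number from compound 2 to compound 4 (0.03 log units; within the scatter), so the series so far separates compound 1 from compounds 2, 3 and 4 but gives no ranking among those three. Compound 1 remains a limit of the assay and not a number, so the full size of each step away from it stays unknown: the limit of > 40000 nM in this assay, at which 1 of the 4 values shown sits.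

The compounds shown leave open whether it is the dimethylamino group that goes with the limit of compound 1, or the whole 4-(dimethylamino)phenyl group; an unsubstituted phenyl or a 4-methoxyphenyl on the same nitrogen would bear on this. They also leave open whether any other group here, such as a phenyl carrying a carboxylic acid or a longer alkyl chain, would give a number outside the scatter of compounds 2, 3 and 4.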